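Trimming the side chain of compound 2 to a propyl

The source may report more compounds than this note shows. Statements on the series, on what has been measured and on what is new or still open speak of the compounds shown alone.

Of the compounds shown here, three that share one core have been measured in a functional assay on OVCAR-8 cells (Homo sapiens) for antiproliferative activity; a lower number here means a stronger inhibitor, a higher number a weaker inhibitor. Compound 1 `CC(=O)OCC[C@@H]1C[C@@H](c2ccc(F)c(F)c2)[C@H](NC(=O)c2cc(-c3c(Cl)cnn3C)c(Cl)o2)CN1` gives 4960 nM. Compound 3 `Cn1ncc(Cl)c1-c1cc(C(=O)N[C@@H]2CN[C@H](CC(O)CO)C[C@H]2c2ccc(F)c(F)c2)oc1Cl` gives 690 nM. Compound 2 `Cn1ncc(Cl)c1-c1cc(C(=O)N[C@@H]2CN[C@H](CCN3CCCC3)C[C@H]2c2ccc(Cl)c(Cl)c2)oc1Cl` gives 1840 nM, which places it second highest of the three numbers, between compound 3 below it and compound 1 above it.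

For the measured compounds named here, the only step between measured compounds that differ in a single place is a 7.2-fold lower number from compound 1 to compound 3 (0.86 log units; beyond the scatter), and it concerns a different part of the side chain from the change considered here.

Compound 4 `CCC[C@@H]1C[C@@H](c2ccc(Cl)c(Cl)c2)[C@H](NC(=O)c2cc(-c3c(Cl)cnn3C)c(Cl)o2)CN1` is compound 2 with methyl in place of pyrrolidin-1-yl on a saturated chain carbon, two bonds along the chain from a saturated ring carbon. Going by the values given here, no measured pair shows this particular change, so the expectation rests on the general picture: alterations to the side chain at this position have moved the number by modest amounts, as in the step from compound 1 to compound 3, while the rest of the molecule stays the same. Because compound 2 gives 1840 nM, compound 4 is expected to land near it, most likely somewhat weaker, with a step of a 1.9-fold higher number from compound 2 to compound 4 (0.28 log units; within the scatter) estimated. The estimate for compound 4 in this assay is 3500 nM, with a range from 1000 nM to 12000 nM.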

Compound 4, half-maximal inhibitory concentration: 1620 nM
For compound 4 the middle estimate is 2.2-fold (0.33 log units) above the measured one; the measured number falls inside the stated range.
By their numbers in this assay, from the lowest: compound 3; then compounds 4 and 2 (each within the scatter of the next); then compound 1.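

Exchanging pyrrolidin-1-yl for methyl on a saturated chain carbon, two bonds along the chain from a saturated ring carbon, gives in this assay a 1.1-fold lower number from compound 2 to compound 4 (0.06 log units; within the scatter), so the pair cannot be told apart. For the compounds shown here, this is the first single-place step at this position that involves a ring and a nitrogen atom: 2-(pyrrolidin-1-yl)ethyl and plain propyl, a chain of carbon alone, both sit within the scatter of each other, which means that in this pair the ring and its nitrogen can be removed without a readable effect on the number. No data at hand explain why the two numbers match.

Going by these compounds, what remains open is whether other groups on this chain would behave the same way, for example a primary amine, a carboxylic acid or a longer chain such as pentyl. On these data alone, it is also open whether the exchange of 2-(pyrrolidin-1-yl)ethyl for propyl would read the same on the core of compound 1, which carries fluorine where compound 2 and compound 4 carry chlorine.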